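Cytotoxicity notes: tert-butyl-oxadiazole replaced by oxime on aryl ether

The compounds below may be only part of what the source reports. "The series", "measured", "known", "first", "only" and "open" are said of these compounds alone.

Measured so far:
compound 1 `CC(CCOc1ccc(-c2noc(C(C)(C)C)n2)cc1)CCN1CCN(c2ccnc(N)c2)C1=O` gives 55000 nM in an ADME assay on RD cells (Homo sapiens) for cytotoxicity, read by MTT assay, with a stated time of 24 h; a higher number here means that more compound is tolerated, a lower number that less compound is tolerated
compound 2 `CCO/N=C/c1ccc(OCC#CCN2CCN(c3ccnc(N)c3)C2=O)cc1` sits at > 100000 nM in this assay, which is a limit of the assay and not a number

In this assay, for the measured compounds named here, compound 1 stands as the only compound with a number; the other value shown is a limit, (the limit of > 100000 nM in this assay, at which 1 of the 2 values shown sits). Compound 3 `CC(CCOc1ccc(/C=N/O)cc1)CCN1CCN(c2ccnc(N)c2)C1=O` differs from compound 1 by a group of 3 heavy atoms (1 carbon, 1 nitrogen, 1 oxygen; no ring) in place of a group of 9 heavy atoms (6 carbon, 2 nitrogen, 1 oxygen; one five-membered aromatic ring with 3 hetero atoms), on an aromatic carbon. Going by the values given here, no measured pair that differs in one place is available, so the size of this step cannot be read from the data. A step beyond the usual scatter is not expected with much confidence; if anything, compound 3 is expected to be tolerated somewhat better than compound 1. Compound 3 is therefore estimated at 80000 nM, with a range from 35000 nM to 180000 nM. The estimated step is a 1.5-fold higher number from compound 1 to compound 3 (0.16 log units; within the scatter), and the assay may well report only a limit for compound 3.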

Compound 3, half-maximal cytotoxic concentration: > 100000 nM
Compound 3 gave a limit, no number (the forecaster's own chance of this, stated with the estimate: 40%); middle value at least 1.2-fold (0.09 log units) from the limit.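

For the compounds shown here, replacing the 5-(tert-butyl)-1,2,4-oxadiazol-3-yl group with the much smaller oxime gives the first readable step at this position in this assay, an at least 1.8-fold higher number from compound 1 to compound 3 (0.25 log units; that floor lies within the scatter). This floor does not separate compound 3 from compound 1 beyond the usual scatter, but the change gives no sign of lower tolerance, and the large aromatic ring is not needed to keep this reading. Compound 3 gives a limit and not a number, so the assay ceiling now bounds most of the readings: the limit of > 100000 nM in this assay, at which 2 of the 3 values shown sit.

Going by these compounds, how far compound 3 lies past that limit remains open, and with it whether the step exceeds the scatter. Also open, on these data alone, is whether an amine or a carboxylic acid on this aromatic carbon would give a number rather than a limit.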